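The compounds below may be only part of what the source reports. "The series", "measured", "known", "first", "only" and "open" are said of these compounds alone.

Measured compounds in a functional assay on HeLa cells (Homo sapiens) for antiproliferative activity, read by MTT assay, with a stated time of 48 h; on this read-out higher numbers stand for weaker inhibition and lower numbers for stronger inhibition:
Compound 1 `Cc1cc2nc(NC(c3cn(-c4ccccc4)nc3-c3ccc([N+](=O)[O-])cc3)c3c(O)ccc4ccccc34)sc2cc1C`: 14700 nM
Compound 2 `Oc1ccc2ccccc2c1C(Nc1nc2ccccc2s1)c1cn(-c2ccccc2)nc1-c1ccccc1`: 17300 nM
Compound 3 `COc1cccc(-c2nn(-c3ccccc3)cc2C(Nc2nc3ccccc3s2)c2c(O)ccc3ccccc23)c1`: 14900 nM

Compound 2 stands level with the other two. Its value of 17300 nM lies within the usual scatter of those of compound 1 and compound 3, so the three cannot be ranked. The next compound, compound 4 `Cc1ccc(-c2nn(-c3ccccc3)cc2C(Nc2nc3ccccc3s2)c2c(O)ccc3ccccc23)cc1`, differs from compound 2 in one place: methyl in place of hydrogen on an aromatic carbon. This is methyl in place of hydrogen on an aromatic carbon, or phenyl to 4-methylphenyl.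

Within the data shown here, no measured step shows this exact change. The nearest evidence is the step of a 1.2-fold lower number from compound 2 to compound 3 (0.06 log units; within the scatter), which puts methoxy in place of hydrogen on an aromatic carbon and stays within the scatter. Compound 1 differs from compound 2 in more than one place, so it offers no single-change comparison, although its value does not stand apart. This is a thin basis of one step, but it gives no reason to expect a shift in either direction in this assay. The expected change is a 1.1-fold lower number from compound 2 to compound 4 (0.03 log units; within the scatter), no step beyond the scatter. For compound 4 the estimated value is 16000 nM, with an expected range from 9000 nM to 28000 nM.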

Compound 4, half-maximal inhibitory concentration: 8050 nM
The estimate for compound 4 lay 2.0-fold (0.30 log units) above the measured number, and the stated range ends above it.
By their numbers in this assay, from the lowest: compounds 4, 1, 3 and 2 (each within the scatter of the next, the first and the last beyond it).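

In this assay, methyl in place of hydrogen on an aromatic carbon, para to a large group, gives a 2.1-fold lower number from compound 2 to compound 4 (0.33 log units; beyond the scatter). Among these compounds, this modest step is the first single change to pass the scatter, since the methoxy change at another place on the same phenyl ring gave only a 1.2-fold lower number from compound 2 to compound 3 (0.06 log units; within the scatter). The comparison of the two substituted rings, 4-methylphenyl in place of 3-methoxyphenyl, gives a 1.9-fold lower number from compound 3 to compound 4 (0.27 log units; within the scatter), so compound 3 and compound 4 cannot be ranked, and the result does not set methyl apart from methoxy; nothing in the data shown accounts for the step from hydrogen to methyl.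

From the compounds shown here alone, what remains open is whether this step is particular to methyl or would also appear with a longer chain such as ethyl, or with a quite different group such as an amine or a carboxylic acid at the same place. It also remains to be seen whether methyl would give a similar step on the other phenyl ring of compound 2, as a single step cannot establish a trend.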